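The source may report more compounds than this note shows. Statements on the series, on what has been measured and on what is new or still open speak of the compounds shown alone.

The measured compounds:

compound 1, `CCOC(=O)N1CCC(NS(=O)(=O)c2ccc(NCCCc3ccccc3)c3ccccc23)CC1`: 32.1 nM
compound 2, `CC(=O)N1CCC(NS(=O)(=O)c2ccc(NC(=O)c3ccccc3C)c3ccccc23)CC1`: 6.7 nM

Both were tested in an assay on L1.2 cells for binding affinity to C-C chemokine receptor type 8 (Homo sapiens); a higher number here means a weaker inhibitor, a lower number a stronger inhibitor. Compound 2 gives the lowest of the two numbers in this assay; compound 1 stands well apart from it, a gap beyond the usual scatter. The two compounds differ at more than one place, so no single change can be read from that pair. Compound 3 `Cc1ccccc1C(=O)Nc1ccc(S(=O)(=O)NC2CCN(C(=O)NC(C)C)CC2)c2ccccc12` has not been measured yet. It differs from compound 2 in one place: isopropylamino in place of methyl on a carbonyl carbon. Among the measured compounds shown here, no measured pair shows this change on its own. Without a comparable step to lean on, the expected change for compound 3 is small, of the size a 1.5-fold higher number from compound 2 to compound 3 (0.17 log units; within the scatter), toward a slightly higher number, within or barely beyond the scatter. Compound 3 is therefore estimated at 10 nM, with a likely range from 3 nM to 35 nM.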

Compound 3, inhibition constant: 77.7 nM
Compound 3: the middle estimate sits 7.8-fold (0.89 log units) below what was measured; measured number outside the range, above it.
By their numbers in this assay, from the lowest: compound 2; then compound 1; then compound 3.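

Among the compounds shown here, this is the first comparison in which only one place changes. On a carbonyl carbon whose other neighbour is an amide-type nitrogen in a ring, isopropylamino in place of methyl gives a 12-fold higher number from compound 2 to compound 3 (1.06 log units; beyond the scatter) in this assay, so affinity is clearly weaker with the isopropylcarbamoyl group than with acetyl. The position is therefore sensitive to what it carries, and the new group differs from methyl both in size and in bringing a hydrogen-bond donor.

The compounds shown cannot separate those two differences: an isobutyryl group would keep the branched carbons without the nitrogen, while methylamino would keep the nitrogen on a smaller group. No measurement shown explains why the number rises.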